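The source may report more compounds than this note shows. Statements on the series, on what has been measured and on what is new or still open speak of the compounds shown alone.

Of the compounds shown here, three have been read so far in a functional assay on KYSE-70 cells for antiproliferative activity against KYSE-70 cell line (Homo sapiens), read by MTT assay, with a stated time of 72 h; a higher number here means a weaker inhibitor, a lower number a stronger inhibitor. Compound 1 `C#CCSc1nc(Sc2nnnn2CCN(C)C)c(C#N)c(-c2ccc(Cl)cc2)n1` gives 6560 nM, and compound 3 `C=CC(=O)Nc1ccccc1CN(C(=O)Nc1cccc(C(F)(F)F)c1)C1CCN(C(C)CCC)CC1` gives 17900 nM. Compound 2 `C#CCSc1nc(Sc2ccccn2)c(C#N)c(-c2cc(OC)c(OC)c(OC)c2)n1` stands at > 10000 nM, which is a limit of the assay and not a number.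

In compound 4 `C#CCSc1nc(Sc2nc[nH]n2)c(C#N)c(-c2cc(OC)c(OC)c(OC)c2)n1`, 1H-1,2,4-triazol-3-yl takes the place of pyridin-2-yl on a sulfur, the difference being (1H-1,2,4-triazol-3-yl in place of pyridin-2-yl on a sulfur). Among the compounds with values here, no measured pair isolates this exchange, and compound 2 offers no exact starting value. The nearest guide, differing from compound 2 in more than one place, is compound 1 at 6560 nM. That value gives only loose support for expecting a reading in the same region, so a small move towards stronger inhibition in this assay is the working expectation, with no change beyond the scatter also plausible. The expected step is an at least 1.1-fold lower number from compound 2 to compound 4 (0.04 log units; that floor lies within the scatter). For compound 4 the estimated value is 9000 nM, with an expected range of 2500 nM to 30000 nM.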

Compound 4, half-maximal inhibitory concentration: > 20000 nM
Compound 4 gave a limit, no number; the forecaster's own chance of this, stated with the estimate: 40%; at least 2.2-fold (0.34 log units) between middle value and limit.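

Within the data shown here, compound 2 and compound 4 both read as limits of the assay and not as numbers, so no step between them can be read. From the compounds shown here alone, whether 1H-1,2,4-triazol-3-yl or pyridin-2-yl on a sulfur gives the stronger inhibition remains open.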